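A few compounds are considered here, and "the series" means these few. Any claim that something is new, unique, unknown or untested is made for them only; others in the source may bear on it.

Measured so far:
Compound 1, `CCC1(Cc2ccccc2)OS(=O)(=O)C=C1OCC(=O)OC`: in an ADME assay on HEL cells (Homo sapiens) for cytotoxicity, with a stated time of 3 days (a higher number here means that more compound is tolerated, a lower number that less compound is tolerated), compound 1 gives > 200000 nM, a limit of the assay.
Compound 2, `CCC1(Cc2ccccc2)OS(=O)(=O)C=C1OCC#N`: in this assay compound 2 gives > 200000 nM, also a limit.
Compound 3, `CCC1(Cc2ccccc2)OS(=O)(=O)C=C1OCc1ccccc1Cl`: in this assay compound 3 gives 38000 nM.

For the measured compounds named here, compound 3 thus holds the only number in the set; the two other values sit at the limit of > 200000 nM in this assay, at which 2 of the 3 values shown sit. Compound 4, `CCC1(Cc2ccccc2)OS(=O)(=O)C=C1OCC1CCCCC1`, differs from compound 3 by cyclohexyl in place of 2-chlorophenyl on a saturated chain carbon bound to an oxygen on an unsaturated carbon. The steps that touch the same place are an at least 5.2-fold lower number from compound 1 to compound 3 (0.72 log units; beyond the scatter) and an at least 5.2-fold lower number from compound 2 to compound 3 (0.72 log units; beyond the scatter), while a step that the two limits leave unreadable from compound 1 to compound 2 stays unreadable. Going by the values given here, no measured step exchanges one six-membered ring for another, so the expected step of a 1.6-fold higher number from compound 3 to compound 4 (0.20 log units; within the scatter) is small, within the scatter or a slight rise. Compound 4 is therefore estimated at 60000 nM, between 20000 nM and 200000 nM.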

Compound 4, half-maximal cytotoxic concentration: > 200000 nM
Compound 4 was reported as a limit; the forecaster's own chance of this, stated with the estimate: 30%; at least 3.3-fold (0.52 log units) between middle value and limit.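

At this place, on a saturated chain carbon bound to an oxygen on an unsaturated carbon, a six-membered ring of carbon only does not by itself bring the lower number: in this assay, cyclohexyl in place of 2-chlorophenyl gives an at least 5.2-fold higher number from compound 3 to compound 4 (0.72 log units; beyond the scatter). The lower number in this set now goes with 2-chlorophenyl alone, not with ring-bearing groups in general. The steps among compound 1, compound 2 and compound 4 cannot be read: the limit of > 200000 nM in this assay, at which 3 of the 4 values shown sit.

On these data alone, whether the chlorine or the aromatic ring goes with the lower number in compound 3 stays open. As far as these compounds go, what an unsubstituted phenyl or an amine at this place would give also stays open.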